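A few compounds are considered here, and "the series" means these few. Any claim that something is new, unique, unknown or untested is made for them only; others in the source may bear on it.

Measured compounds:
compound 1 `COC(=O)CCCCc1cnc(C(=O)CCCCCCc2ccccc2)o1` — 1.8 nM
compound 2 `O=C(O)CCCCc1cnc(C(=O)CCCCCCc2ccccc2)o1` — 23.8 nM
compound 3 `O=C(CCCCCCc1ccccc1)c1ncc(CCCCCO)o1` — 10.1 nM

In an assay for inhibition of Fatty-acid amide hydrolase 1 (Rattus norvegicus), using a Dixon plot (on this read-out lower numbers stand for stronger inhibition and higher numbers for weaker inhibition), compound 3 stands second highest of the three numbers; the nearest is compound 2 with 23.8 nM, the furthest compound 1 with 1.8 nM. Compound 4 `O=C(CCCCCCc1ccccc1)c1ncc(CCCCCBr)o1` differs from compound 3 by bromo in place of hydroxy on a saturated chain carbon, five bonds along the chain from an aromatic carbon. Among the measured compounds shown here, no measured step touches the hydroxy itself; the steps at the end of this chain, a 5.6-fold higher number from compound 1 to compound 3 (0.75 log units; beyond the scatter) and a 2.4-fold lower number from compound 2 to compound 3 (0.37 log units; beyond the scatter), were modest, while a 13-fold higher number from compound 1 to compound 2 (1.12 log units; beyond the scatter) was large. A modest step is therefore expected here, with the direction uncertain; the estimate leans to a lower number, a 1.7-fold lower number from compound 3 to compound 4 (0.23 log units; within the scatter). Compound 4 is expected at 6 nM, within 2 nM to 20 nM.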

Compound 4, inhibition constant: 6.1 nM
The estimate for compound 4 lay 1.0-fold (0.01 log units) below the measured number; measured number inside the range.
By their numbers in this assay, from the lowest: compound 1; then compounds 4 and 3 (each within the scatter of the next); then compound 2.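

In this assay, bromo in place of hydroxy on a saturated chain carbon, five bonds along the chain from an aromatic carbon, gives a 1.7-fold lower number from compound 3 to compound 4 (0.22 log units; within the scatter), so losing the hydroxy's hydrogen-bond donor and acceptor does not shift the number beyond the scatter. Against the carboxy end, bromomethyl gives a 3.9-fold lower number from compound 2 to compound 4 (0.59 log units; beyond the scatter), while against the methoxycarbonyl end it gives a 3.4-fold higher number from compound 1 to compound 4 (0.53 log units; beyond the scatter), so the methyl ester keeps its edge over bromomethyl. No available evidence explains these steps. On these data alone, whether an amine or a nitrile at this chain end would fit the same range remains open, as does the effect of a longer chain carrying bromo.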